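Para-methyl analogue of the benzyloxy chalcone series

The source may report more compounds than this note shows. Statements on the series, on what has been measured and on what is new or still open speak of the compounds shown alone.

Compound 3 `O=C(/C=C/c1cccc(OCc2ccccc2)c1)c1ccccc1` carries an unsubstituted phenyl on the carbonyl. In an ADME assay on HEK293 cells (Homo sapiens) for cytotoxicity, read by MTT assay, with a stated time of 68 h (a lower number here means a stronger inhibitor, a higher number a weaker inhibitor), compound 3 gives 14100 nM, the second highest of the three numbers measured. Compound 1 `O=C(/C=C/c1cccc(OCc2ccccc2)c1)c1ccc(Br)cc1` gives 5400 nM and compound 2 `O=C(/C=C/c1cccc(OCc2ccccc2)c1)c1ccc(Cl)cc1Cl` gives 24900 nM. The bromo analogue stands out: a 2.6-fold higher number from compound 1 to compound 3 (0.42 log units; beyond the scatter), a modest step beyond the scatter, while a 1.8-fold lower number from compound 2 to compound 3 (0.25 log units; within the scatter) stays within it and a 4.6-fold higher number from compound 1 to compound 2 (0.66 log units; beyond the scatter) is modest.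

Compound 4 `Cc1ccc(C(=O)/C=C/c2cccc(OCc3ccccc3)c2)cc1` differs from compound 3 by methyl in place of hydrogen on an aromatic carbon. For the measured compounds named here, the closest precedent is the step in the other direction from compound 3 to compound 1, where a bromo enters at the same kind of aromatic carbon and the number falls by a 2.6-fold higher number from compound 1 to compound 3 (0.42 log units; beyond the scatter) read backwards. Going by the values given here, a methyl is not a halogen, and no methyl-bearing compound has been measured here, so the precedent is only loose. The dichloro steps bear little, as they change two positions at once.

The expectation is a small lowering of the number or none beyond the scatter: compound 4 is estimated at 9500 nM, with a likely range of 4000 nM to 22000 nM, corresponding to an expected step of a 1.5-fold lower number from compound 3 to compound 4 (0.17 log units; within the scatter).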

Compound 4, half-maximal inhibitory concentration: 8200 nM
Estimate against measurement, compound 4: 1.2-fold (0.06 log units) above, within the range that was stated.
By their numbers in this assay, from the lowest: compounds 1, 4, 3 and 2 (each within the scatter of the next, the first and the last beyond it).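

Notes on the para position: in this assay, methyl in place of hydrogen on this aromatic carbon gives a step that stays within the scatter (a 1.7-fold lower number from compound 3 to compound 4 (0.24 log units; within the scatter)), and methyl in place of bromo on the same carbon does likewise (a 1.5-fold higher number from compound 1 to compound 4 (0.18 log units; within the scatter)). Compound 4 therefore cannot be separated from either of these two neighbours, even though the bromo and hydrogen analogues are separated from each other by a modest step beyond the scatter (a 2.6-fold higher number from compound 1 to compound 3 (0.42 log units; beyond the scatter)), so methyl reads as an intermediate case that this assay does not resolve from either. For the compounds shown here, the one step from compound 4 that lies beyond the scatter is the modest change of 4-methylphenyl in place of 2,4-dichlorophenyl (a 3.0-fold lower number from compound 2 to compound 4 (0.48 log units; beyond the scatter)), and that change alters two ring positions at once, so it does not isolate the methyl.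

No measurement shown here gives a reason for any of these steps. Still open, going by these compounds, is whether a methoxy group or an amine on the same aromatic carbon would stay within this narrow band or move the number beyond the scatter.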